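Fluoro and Methyl Changes in an Acid Dissociation Series

The compounds below may be only part of what the source reports. "The series", "measured", "known", "first", "only" and "open" are said of these compounds alone.

Compound 1, `O=S(=O)(Nc1ccccc1)c1ccccc1`: 9.1
Compound 2, `O=S(=O)(Nc1ccc(F)cc1)c1ccccc1`: 8.85
Compound 3, `Cc1ccc(NS(=O)(=O)c2ccccc2)cc1`: 9.34

These three compounds have been measured in a physicochemical assay for acid dissociation. Compound 2 differs from compound 1 by fluoro in place of hydrogen on an aromatic carbon, and this change gave a number 0.25 log units lower from compound 1 to compound 2 (within the scatter). Compound 3 differs from compound 1 by methyl in place of hydrogen on an aromatic carbon, which gave a number 0.24 log units higher from compound 1 to compound 3 (within the scatter). Between the two changed compounds the gap is a number 0.49 log units higher from compound 2 to compound 3 (beyond the scatter).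

Compound 4, `Cc1ccc(NS(=O)(=O)c2ccc(F)cc2)cc1`, has not yet been measured in this assay. It differs from compound 3 by fluoro in place of hydrogen on an aromatic carbon. This is the same change as that made from compound 1 to compound 2, and among the compounds shown it occurs twice in all, with its place described in the same words both times. Within the data shown here, its one measured instance was a number 0.25 log units lower from compound 1 to compound 2 (within the scatter). On that single step alone rests the expectation for compound 4, whose step is estimated to be a number 0.29 log units lower from compound 3 to compound 4 (within the scatter). Compound 4 is therefore expected to give about 9.05 in this assay, with most repeat measurements expected to fall between 8.7 and 9.4.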

Compound 4, acid dissociation constant: 9.23
Beside the measured number, compound 4's estimate is 0.18 log units below it, within the range that was stated.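

In this assay the fluoro change gave a number 0.11 log units lower from compound 3 to compound 4 (within the scatter) on the methyl-bearing core of compound 3, and its earlier instance gave a number 0.25 log units lower from compound 1 to compound 2 (within the scatter) on the core of compound 1. Both instances therefore stay within the scatter, so the change carried from one core to the other without a shift that can be told from repeat variation on either core. This does not show that fluoro has a real, constant effect in this series, since it rests on only two steps, neither of them distinct from no change, and nothing shown accounts for the result.

The compounds shown leave open whether a nitrile, a trifluoromethyl or a carboxylic acid in place of the fluoro would give a step beyond the scatter. They also leave open whether the fluoro change would behave in the same way on a core carrying a methoxy or an amine instead of the methyl.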